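Aryl Swap on an Oxadiazole Core in a Whole-Insect Assay

The compounds below may be only part of what the source reports. "The series", "measured", "known", "first", "only" and "open" are said of these compounds alone.

Compound 1, `CC(C)(C)n1ncc(OCc2nnc(-c3ccc(Br)cc3)o2)c(Cl)c1=O`, gives 21.4 ug/mL in a functional assay on the whole organism for inhibition, with Mythimna separata as the target, with a stated time of 5 days; on this read-out higher numbers stand for an effect only at larger amounts of compound and lower numbers for an effect already at smaller amounts. Compound 2, `Cc1cc(C)cc(-c2nnc(COc3cnn(C(C)(C)C)c(=O)c3Cl)s2)c1`, reaches only the limit > 300 ug/mL in this assay. Compound 3, `Cc1cc(C)cc(-c2nnc(COc3cnn(C(C)(C)C)c(=O)c3Cl)o2)c1`, likewise reaches only the limit > 300 ug/mL in this assay.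

Compound 3 thus stands at the upper edge of what this assay reports, and it shares that position with compound 2: the limit of > 300 ug/mL in this assay, at which 2 of the 3 values shown sit. The change to compound 4, `CC(C)(C)n1ncc(OCc2nnc(-c3c(F)cccc3F)o2)c(Cl)c1=O`, is 2,6-difluorophenyl in place of 3,5-dimethylphenyl on an aromatic carbon. Within the data shown here, the only measured step at this position is an at least 14-fold higher number from compound 1 to compound 3 (1.14 log units; beyond the scatter), where a 4-bromophenyl gave a number while the 3,5-dimethylphenyl did not. Compound 4 returns to a halogenated phenyl, though with a different pattern, so a lower number than for compound 3 is expected, estimated at 80 ug/mL (range 15 ug/mL to 300 ug/mL), a step of an at least 3.7-fold lower number from compound 3 to compound 4 (0.57 log units; beyond the scatter).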

Compound 4, half-maximal effective concentration: 45.4 ug/mL
Beside the measured number, compound 4's estimate is 1.8-fold (0.25 log units) above it, and the stated range covers the measured number.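

Replacing the 3,5-dimethylphenyl with 2,6-difluorophenyl gives an at least 6.6-fold lower number from compound 3 to compound 4 (0.82 log units; beyond the scatter), so a measured number at this position does not depend on the 4-bromophenyl of compound 1. The two halogenated phenyl groups do not match, however: the second swap gives a 2.1-fold higher number from compound 1 to compound 4 (0.33 log units; beyond the scatter). The first step has only a bound, since compound 3 sits at a limit: the limit of > 300 ug/mL in this assay, at which 2 of the 4 values shown sit.

The compounds shown leave open how a phenyl carrying a methoxy group or a nitrile would read at this position. They also leave open whether a single fluorine would serve as well as two.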